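A few compounds are considered here, and "the series" means these few. Any claim that something is new, unique, unknown or untested is made for them only; others in the source may bear on it.

Measured in a functional assay on CCRF-CEM cells (Homo sapiens) for cytotoxicity, in the absence of a further agent; on this read-out higher numbers stand for weaker inhibition and lower numbers for stronger inhibition:
Compound 1 `Nc1nc(N)c(CCCNc2cc(F)ccc2[N+](=O)[O-])c(O)n1`: > 100000 nM
Compound 2 `Nc1nc(N)c(CCCNc2cc(F)cc(F)c2[N+](=O)[O-])c(O)n1`: 97000 nM

Compound 1 gives no number, only a limit, and stands at the limit of > 100000 nM in this assay, at which 1 of the 2 values shown sits. Compound 3 `COC(=O)c1ccc(CN(CCCc2c(N)nc(N)nc2O)c2cc(F)ccc2[N+](=O)[O-])cc1` differs from compound 1 by 4-(methoxycarbonyl)benzyl in place of hydrogen on a nitrogen on an aromatic ring. Among the measured compounds shown here, the one measured step, an at least 1.0-fold lower number from compound 1 to compound 2 (0.01 log units; that floor lies within the scatter), is fluoro in place of hydrogen on an aromatic carbon. Its floor lies within the scatter, and it does not test this change. For the measured compounds named here, with compound 2 at 97000 nM as the only number, a small move toward stronger inhibition in this assay is expected, or none beyond the scatter. The estimated step is an at least 1.6-fold lower number from compound 1 to compound 3 (0.22 log units; that floor lies within the scatter). For compound 3 the expected value is 60000 nM, with an estimated range of 15000 nM to 100000 nM.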

Compound 3, half-maximal inhibitory concentration: 45000 nM
Compound 3: the middle estimate sits 1.3-fold (0.12 log units) above what was measured, within the range that was stated.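

In this assay placing 4-(methoxycarbonyl)benzyl on the nitrogen on an aromatic ring gives an at least 2.2-fold lower number from compound 1 to compound 3 (0.34 log units; beyond the scatter) and so shows a step that the fluoro change did not. This nitrogen therefore accepts the group with no loss of inhibition and at least a modest gain. The true size of the step stays unknown because compound 1 gives only a limit: the limit of > 100000 nM in this assay, at which 1 of the 3 values shown sits.

The compounds shown leave open whether the step comes from the benzyl ring alone or needs the methyl ester, which a plain benzyl or a carboxylic acid in its place would separate. They also leave open whether a longer chain between this nitrogen and the benzene ring would serve equally well.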